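The compounds below may be only part of what the source reports. "The series", "measured", "known", "first", "only" and "open" are said of these compounds alone.

Compound 1 `COc1ccc(C(=O)Nc2nn(-c3ccccc3)c(=O)c3ccccc23)cc1` gives 10% in an assay on CHO cells for displacement of a labelled ligand from adenosine receptor A3 (Homo sapiens), tested at 1 uM; on this read-out higher numbers stand for more inhibition at the one concentration tested (going by the name of the read-out) and lower numbers for less inhibition.
Compound 2 `O=C(Nc1nn(-c2ccccc2)c(=O)c2ccccc12)c1ccc(Cl)cc1` gives 17% in this assay.

Compound 2 stands highest of the two numbers, but its nearest neighbour, compound 1, lies within the scatter of it, so the two cannot be placed in order. Going by the values given here, the only measured step, a number 7 percentage points higher from compound 1 to compound 2 (within the scatter), is within the scatter as well, and it concerns a chloro in place of a methoxy on an aromatic carbon, which is a different kind of change from the one now considered.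

Compound 3 `Cc1ccccc1NC(=O)Nc1nn(-c2ccccc2)c(=O)c2ccccc12` differs from compound 2 in this way: (2-methylphenyl)amino in place of 4-chlorophenyl on a carbonyl carbon. Among the compounds with values here, no measured step bears directly on this exchange; the one step available is small and touches only a substituent on the aromatic ring that is now removed. With both measured compounds low and close to each other, the step of a number 2 percentage points lower from compound 2 to compound 3 (within the scatter) is expected to stay within the scatter. In this assay compound 3 is therefore estimated at 15%, with a range from 0% to 40%.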

Compound 3, a percentage reported as inhibition, at one concentration (the size of the read-out at that concentration, not a potency): 22%
Estimate against measurement, compound 3: 7 percentage points below; the range from low to high includes it.
By their numbers in this assay, from the lowest: compounds 1, 2 and 3 (each within the scatter of the next, the first and the last beyond it).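

In this assay, the carbonyl carbon accepts an exchange of a whole group, not just of a substituent on the ring: putting (2-methylphenyl)amino in place of 4-chlorophenyl gives a number 5 percentage points higher from compound 2 to compound 3 (within the scatter), so this larger change, which brings in a nitrogen with one hydrogen-bond donor, cannot be told apart from no change at all. Going by these compounds alone, the same group in place of 4-methoxyphenyl gives a number 12 percentage points higher from compound 1 to compound 3 (beyond the scatter), the first step to clear the scatter, although it is modest and the numbers all remain low at the one concentration tested. Nothing measured here accounts for either step.

The exchange alters the atom on the carbonyl carbon and the ring substituent together, so the contributions of the amino nitrogen and of the 2-methyl group remain unseparated, and an unsubstituted phenylamino group would be needed to divide them. Going by these compounds, it also remains open whether a group with no aromatic ring on this carbonyl carbon, such as a morpholine or a short alkyl chain, would give a number beyond the scatter of these three.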